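The compounds below may be only part of what the source reports. "The series", "measured", "known", "first", "only" and "open" are said of these compounds alone.

Compound 1 `Cc1ccccc1-n1nncc1CN1C(=O)C2(C(C#N)=C(N)Oc3c(N)cc4nc5ccccc5nc4c32)c2ccccc21` gives 31700 nM in a functional assay on A549 cells (Homo sapiens) for antiproliferative activity, read by MTT assay, with a stated time of 48 h; a higher number here means a weaker inhibitor, a lower number a stronger inhibitor.
Compound 2 `COc1ccccc1-n1nncc1CN1C(=O)C2(C(C#N)=C(N)Oc3c(N)cc4nc5ccccc5nc4c32)c2ccccc21` gives 37500 nM in this assay.

Among the compounds with values here, only two compounds have been measured, and their numbers sit close together: the step from compound 1 to compound 2, a 1.2-fold higher number from compound 1 to compound 2 (0.07 log units; within the scatter), is within the scatter, so compound 2 stands level with compound 1 rather than apart from it. Compound 3 `CCOc1ccc(-n2nncc2CN2C(=O)C3(C(C#N)=C(N)Oc4c(N)cc5nc6ccccc6nc5c43)c3ccccc32)cc1` is not yet measured. It differs from compound 2 by 4-ethoxyphenyl in place of 2-methoxyphenyl on an aromatic nitrogen. Within the data shown here, the one measured step, from compound 1 to compound 2, exchanged a methyl for a methoxy on the same phenyl ring and produced no shift beyond the scatter. Among the measured compounds shown here, no measured pair speaks to moving the substituent to the 4-position of the phenyl ring or to lengthening methoxy to ethoxy, so the expectation rests on the single flat step alone. On that basis the step from compound 2 to compound 3 in this assay is expected to be small, a 1.1-fold lower number from compound 2 to compound 3 (0.03 log units; within the scatter), with no direction that can be trusted. Compound 3 is therefore estimated at 35000 nM, within a range from 14000 nM to 90000 nM.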

Compound 3, half-maximal inhibitory concentration: > 50000 nM
Compound 3 ended at the assay's limit; the forecaster's own chance of this, stated with the estimate: 10%; middle value at least 1.4-fold (0.15 log units) away from the limit.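

Compound 3 in this assay gives > 50000 nM, which is a limit of the assay and not a number: the limit of > 50000 nM in this assay, at which 1 of the 3 values shown sits.

On the aromatic nitrogen of the five-membered ring, putting 4-ethoxyphenyl in place of 2-methoxyphenyl gives an at least 1.3-fold higher number from compound 2 to compound 3 (0.12 log units; that floor lies within the scatter), and putting it in place of 2-methylphenyl gives an at least 1.5-fold higher number from compound 1 to compound 3 (0.19 log units; that floor lies within the scatter). Within the data shown here, the earlier exchange of methyl for methoxy showed only that one change on the phenyl ring left the reading flat, whereas this change shows that a different substitution pattern on that ring brought no gain in strength, although both floors lie within the scatter and the true size of the steps cannot be read.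

Compound 3 differs from compound 2 both in where the group sits on the phenyl ring and in its chain, ethoxy against methoxy, and no compound shown separates these two changes. Also open, on these data alone, is how the series would read in this assay with an amine, a carboxylic acid or a longer chain such as butoxy on that phenyl ring.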